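A few compounds are considered here, and "the series" means these few. Any claim that something is new, unique, unknown or untested is made for them only; others in the source may bear on it.

Going by the values given here, in a functional assay on HepG2 cells (Homo sapiens) for inhibition, read by MTT assay, with a stated time of 120 h (on this read-out lower numbers stand for stronger inhibition and higher numbers for weaker inhibition), compound 1 `CNC(=O)C#Cc1ccc(NC(=O)Nc2ccc(Cl)c(C(F)(F)F)c2)cc1` gives 23300 nM, the only value among the two measured compounds that is a number. Compound 2 `C/C(=C\c1ccc(NC(=O)Nc2ccc(Cl)c(C(F)(F)F)c2)cc1)C(=O)N1CC(C)OC(C)C1` is reported at > 50000 nM, which is a limit of the assay and not a number. Among the compounds with values here, that second value therefore sits at the limit of > 50000 nM in this assay, at which 1 of the 2 values shown sits, so compound 1 is the only compound with a real place on the scale.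

Compound 3 `CNC(=O)/C=C(\C)c1ccc(NC(=O)Nc2ccc(Cl)c(C(F)(F)F)c2)cc1` has not yet been measured. It differs from compound 1 in one place: 1-methyl-2-(methylcarbamoyl)ethenyl in place of 2-(methylcarbamoyl)ethynyl on an aromatic carbon. Within the data shown here, no two measured compounds differ from each other in a single place, so there is no measured step to lean on, and the size of this change has to be judged from the two values alone.

The expectation is that the step from compound 1 to compound 3 is a 1.5-fold higher number from compound 1 to compound 3 (0.18 log units; within the scatter), a small loss that may not reach beyond the usual scatter. On that basis the estimated value of compound 3 in this assay is 35000 nM, with a range from 12000 nM to 100000 nM.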

Compound 3, half-maximal inhibitory concentration: > 50000 nM
Compound 3 gave a limit, no number (the forecaster's own chance of this, stated with the estimate: 35%); middle value at least 1.4-fold (0.15 log units) away from the limit.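

In this assay, putting 1-methyl-2-(methylcarbamoyl)ethenyl in place of 2-(methylcarbamoyl)ethynyl on the aromatic carbon gives an at least 2.1-fold higher number from compound 1 to compound 3 (0.33 log units; beyond the scatter), so this change costs activity by more than the usual scatter, even though compound 1 was already weak. Compound 3 gives > 50000 nM, which is a limit of the assay and not a number, so the step sets only a lower bound on the loss. This is the only measured single change at the place para to a large group, and it leaves compound 1 as the only compound with a real position on the scale: the limit of > 50000 nM in this assay, at which 2 of the 3 values shown sit.

The compounds shown leave open whether the loss comes from the added methyl or from the triple bond giving way to a double bond, since both changes arrive together in compound 3. They also leave open how this assay would read with a different group at the same place, such as a simple nitrile, a carboxylic acid or an amine.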